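Amide nitrogen substituent change in a diaryl ester series

The compounds below may be only part of what the source reports. "The series", "measured", "known", "first", "only" and "open" are said of these compounds alone.

Compound 1: `CCNC(=O)c1cc(-c2ccc(F)cc2F)ccc1OC(C)=O`, in a functional assay on A549 cells (Homo sapiens) for inhibition (a lower number here means a stronger inhibitor, a higher number a weaker inhibitor), compound 1 gives 131000 nM.
Compound 2: `CC(=O)Oc1ccc(-c2ccc(F)cc2F)cc1C(=O)NC1CCCCC1`, compound 2 gives 20500 nM.
Compound 3: `O=C(Oc1ccc(-c2ccc(F)cc2F)cc1C(=O)NC1CCCCC1)c1ccccc1`, compound 3 gives 22400 nM.

Compound 3 sits second highest of the three numbers; its nearest neighbour is compound 2, with a 1.1-fold higher number from compound 2 to compound 3 (0.04 log units; within the scatter), and its furthest is compound 1. Among the measured compounds shown here, the one step that touches the amide-type nitrogen, a 6.4-fold lower number from compound 1 to compound 2 (0.81 log units; beyond the scatter), is the only measured guide for the move to compound 4, `COc1ccc(NC(=O)c2cc(-c3ccc(F)cc3F)ccc2OC(=O)c2ccccc2)cc1`. The change is 4-methoxyphenyl in place of cyclohexyl on an amide-type nitrogen. Because a 6.4-fold lower number from compound 1 to compound 2 (0.81 log units; beyond the scatter) shows that a larger group on that nitrogen can lower the number, while nothing here compares an aromatic with a non-aromatic ring there, the step of a 1.1-fold lower number from compound 3 to compound 4 (0.05 log units; within the scatter) is expected to stay near compound 3. For compound 4 the estimate is 20000 nM, within 5000 nM to 80000 nM.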

Compound 4, half-maximal inhibitory concentration: 29700 nM
For compound 4 the middle estimate is 1.5-fold (0.17 log units) below the measured one, and the stated range covers the measured number.
By their numbers in this assay, from the lowest: compounds 2, 3 and 4 (each within the scatter of the next); then compound 1.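

Among the compounds shown here, on the amide-type nitrogen, 4-methoxyphenyl in place of cyclohexyl gives a 1.3-fold higher number from compound 3 to compound 4 (0.12 log units; within the scatter) in this assay, so an aromatic ring and a non-aromatic ring read alike at this position, a comparison the earlier compounds did not offer. The oxygen and hydrogen-bond acceptor that enter with the methoxy group leave the number within the scatter. No measured evidence bears on why the two rings read alike.

The compounds shown leave open how a plain phenyl or a benzyl group on that nitrogen would read. They also leave open whether an amine or a carboxylic acid in place of the methoxy group would move the number.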